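Changing the Aryl Group on the Sulfonyl Sulfur

The source may hold more compounds than are shown below. What is called first, only, known or untested is meant among the compounds shown, and "the series" means these compounds.

Measured compounds in a functional assay (Cavia porcellus) with sulfonylurea receptors; K-ATP channels (Homo sapiens) as the target; a higher number here means a weaker inhibitor, a lower number a stronger inhibitor:
Compound 1, `CC(O)(C(=O)Nc1ccc(S(=O)(=O)c2ccc(F)cc2)cc1)C(F)(F)F`: 8600 nM
Compound 2, `CC(O)(C(=O)Nc1ccc(S(=O)(=O)c2ccccc2C#N)cc1)C(F)(F)F`: 1100 nM
Compound 3, `COc1cccc(S(=O)(=O)c2ccc(NC(=O)C(C)(O)C(F)(F)F)cc2)c1`: 16000 nM

All three share one core and differ only in the aryl group on the sulfonyl sulfur. Compound 3 shows the highest number of the three. Its gap to compound 1 is small: a 1.9-fold higher number from compound 1 to compound 3 (0.27 log units; within the scatter). Its gap to compound 2 is wide: a 15-fold higher number from compound 2 to compound 3 (1.16 log units; beyond the scatter). The other measured step, a 7.8-fold lower number from compound 1 to compound 2 (0.89 log units; beyond the scatter), points the same way, so the 2-cyanophenyl compound stands apart from the other two.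

Compound 4, `Cc1ccccc1S(=O)(=O)c1ccc(NC(=O)C(C)(O)C(F)(F)F)cc1`, is not yet measured. The change from compound 3 is 2-methylphenyl in place of 3-methoxyphenyl on a sulfonyl sulfur. Going by the values given here, no measured step swaps a 3-methoxyphenyl for a 2-methylphenyl, so the expectation can only lean on the steps above. Among the compounds with values here, both steps ending at or starting from compound 2 carry a group placed in the 2-position, and the only such group measured lowered the number clearly. A methyl is not a nitrile, so the expected effect is set smaller and given a wide range.

For compound 4 in this assay the expected step is a 4.0-fold lower number from compound 3 to compound 4 (0.60 log units; beyond the scatter), and the estimated value is 4000 nM, within a range from 1300 nM to 12000 nM.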

Compound 4, half-maximal inhibitory concentration: 5100 nM
Compound 4: the middle estimate sits 1.3-fold (0.11 log units) below what was measured; measured number inside the range.
By their numbers in this assay, from the lowest: compound 2; then compounds 4, 1 and 3 (each within the scatter of the next, the first and the last beyond it).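

In this assay, 2-methylphenyl in place of 3-methoxyphenyl on the sulfonyl sulfur gives a step beyond the scatter (a 3.1-fold lower number from compound 3 to compound 4 (0.50 log units; beyond the scatter)), so this aryl group can shift the number without any nitrile present. Against the 4-fluorophenyl group, however, 2-methylphenyl cannot be told apart (a 1.7-fold lower number from compound 1 to compound 4 (0.23 log units; within the scatter)), which leaves compound 4 in the same loose group as compound 1. The clearest new comparison changes a single substituent on the same aromatic carbon, and methyl in place of cyano raises the number beyond the scatter (a 4.6-fold higher number from compound 2 to compound 4 (0.67 log units; beyond the scatter)), so compound 2 remains the strongest inhibitor of the four and its nitrile matters, not merely the presence of some group at that place. Nothing measured here explains why the nitrile and the methyl give different numbers.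

From the compounds shown here alone, whether an amine, a carboxylic acid or a longer chain such as ethyl on that same aromatic carbon would give a number closer to compound 2 or to compound 4 stays open. So does whether the nitrile would keep its advantage on a changed core.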